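This account rests on a few compounds, and the source may have more. Where it says the series, first, only, none or still open, it means among the compounds named here.

Working notes on the series.

Compound 1, `C=CCONC(=O)CN1C(=O)S/C(=C\c2cccc(C(=O)N[C@@H](CC(C)C)C(=O)OC)c2)C1=O`, is the reference point. In a functional assay on MRC5 cells (Homo sapiens) for inhibition, read by microscopy and resazurin assay, with a stated time of 72 h (a lower number here means a stronger inhibitor, a higher number a weaker inhibitor), compound 1 gives > 128000 nM, which is a limit of the assay and not a number. Compound 2, `COC(=O)[C@H](CC(C)C)NC(=O)c1cccc(/C=C2\SC(=O)N(CC(=O)NOCc3ccccc3)C2=O)c1`, differs from compound 1 by phenyl in place of vinyl on a saturated chain carbon bound to an oxygen on an unsaturated carbon. In this assay compound 2 gives > 128000 nM, again a limit of the assay. The step that the two limits leave unreadable from compound 1 to compound 2 is therefore unreadable in size and direction, because of the limit of > 128000 nM in this assay, at which 2 of the 2 values shown sit. For the measured compounds named here, compound 1 stands at a limit only, and the one further value shown is likewise a limit.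

Compound 3, `C=CCONC(=O)CN1C(=O)S/C(=C\c2cccc(C(=O)N[C@H](C(=O)OC)C(C)C)c2)C1=O`, is not yet measured. It differs from compound 1 by isopropyl in place of isobutyl on a saturated chain carbon bound to an amide-type nitrogen and a carbonyl carbon. Going by the values given here, no measured step bears on this change, and the only measured step from compound 1 is itself unreadable. On the evidence shown, compound 3 is expected to remain at the limit, with an estimated step that the limit leaves unreadable from compound 1 to compound 3. Compound 3 is estimated at 200000 nM, in the range 128000 nM to 600000 nM.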

Compound 3, half-maximal inhibitory concentration: > 128000 nM
Compound 3: only a limit was reported; the forecaster's own chance of this, stated with the estimate: 85%; the middle value does not contradict the limit.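

In this assay compound 3 gives > 128000 nM, a limit of the assay and not a number. The step from compound 1 to compound 3 therefore cannot be read: the limit of > 128000 nM in this assay, at which 3 of the 3 values shown sit.

The compounds shown leave open how far compound 1, compound 2 and compound 3 each lie from that limit, and whether either change alters inhibition at all.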